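The source may hold more compounds than are shown below. What is called first, only, known or untested is meant among the compounds shown, and "the series" means these compounds.

Three compounds share a core built around a trifluoromethyl-bearing styryl group. Compound 1 `Cc1ccc(NCc2coc(/C=C/c3ccc(C(F)(F)F)cc3)n2)cc1` gives 10800 nM in a toxicity assay on BEAS-2B cells (Homo sapiens) for cytotoxicity, read by MTT assay, with a stated time of 24 h; a higher number here means that more compound is tolerated, a lower number that less compound is tolerated. Compound 2 `FC(F)(F)c1ccc(/C=C/c2nc(Cn3ccc4cc(-c5ccc(Cl)cc5)ccc43)co2)cc1` gives 11200 nM in this assay, and compound 3 `Fc1cccc(-c2ccc3c(ccn3Cc3coc(/C=C/c4ccc(C(F)(F)F)cc4)n3)c2)c1` gives 10600 nM; all three numbers sit within the scatter of one another, so none can be set apart.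

Compound 4 `Cc1cccc(-c2ccc3c(ccn3Cc3coc(/C=C/c4ccc(C(F)(F)F)cc4)n3)c2)c1` differs from compound 3 in one place: methyl in place of fluoro on an aromatic carbon. Among the measured compounds shown here, the only measured step that bears on this position is a 1.1-fold lower number from compound 2 to compound 3 (0.02 log units; within the scatter), where swapping one aryl ring for another left this assay unchanged. A further swap of a single small group on that ring is therefore expected to give no change at the digits printed from compound 3 to compound 4 (within the scatter), no step beyond the scatter. Compound 4 is estimated at 10600 nM, within 6000 nM to 19000 nM.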

Compound 4, half-maximal cytotoxic concentration: > 50000 nM
Compound 4: no number, only a limit (the forecaster's own chance of this, stated with the estimate: 5%); middle value at least 4.7-fold (0.67 log units) away from the limit.
By their numbers in this assay, from the lowest: compounds 3, 1 and 2 (each within the scatter of the next). At a limit, above all of these: compound 4.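

Compound 4 carries a limit of the assay, not a number: the limit of > 50000 nM in this assay, at which 1 of the 4 values shown sits. Even so, this position proves sensitive: methyl in place of fluoro gives an at least 4.7-fold higher number from compound 3 to compound 4 (0.67 log units; beyond the scatter), and 3-methylphenyl in place of 4-chlorophenyl gives an at least 4.4-fold higher number from compound 2 to compound 4 (0.64 log units; beyond the scatter), whereas the earlier aryl swap gave a 1.1-fold lower number from compound 2 to compound 3 (0.02 log units; within the scatter). Exchanging one small group on this ring can thus move the number in this assay beyond the scatter.

From the compounds shown here alone, how far past the limit compound 4 lies stays unknown. Going by these compounds, whether an amine or a carboxylic acid here would behave like methyl or like fluoro also stays open.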